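The source may report more compounds than this note shows. Statements on the series, on what has been measured and on what is new or still open speak of the compounds shown alone.

Measured compounds:
compound 1 `CCC(C)(O)CC(=O)O[C@H](CC=C(C)C)C1=CC(=O)c2c(O)ccc(O)c2C1=O` — 25200 nM
compound 2 `CC(C)=CC[C@@H](OC(=O)CC(C)(O)c1ccccc1)C1=CC(=O)c2c(O)ccc(O)c2C1=O` — 85700 nM
compound 3 `CC(C)=CC[C@@H](OC(=O)c1ccco1)C1=CC(=O)c2c(O)ccc(O)c2C1=O` — 80300 nM

In a functional assay on HeLa cells (Homo sapiens) for cytotoxicity, read by MTT assay (on this read-out lower numbers stand for stronger inhibition and higher numbers for weaker inhibition), compound 2 gives the highest of the three numbers. Compound 3 is nearest, the gap being a 1.1-fold lower number from compound 2 to compound 3 (0.03 log units; within the scatter), and compound 1 is furthest, the gap being a 3.4-fold higher number from compound 1 to compound 2 (0.53 log units; beyond the scatter). Compound 4 `CC(C)=CC[C@@H](OC(=O)CCO)C1=CC(=O)c2c(O)ccc(O)c2C1=O` differs from compound 2 by hydroxymethyl in place of 1-hydroxy-1-phenylethyl on a saturated chain carbon bound to a carbonyl carbon. The step from compound 1 to compound 2 bears most directly on this change, since it introduced the phenyl on a saturated chain carbon that compound 4 now drops again, and it was modest but beyond the scatter. The step from compound 2 to compound 3 stayed within the scatter and adds little direction. Compound 4 is therefore expected to fall back toward compound 1, with a 2.4-fold lower number from compound 2 to compound 4 (0.39 log units; beyond the scatter). Compound 4 is estimated at 35000 nM, in a range from 12000 nM to 100000 nM.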

Compound 4, half-maximal inhibitory concentration: 67600 nM
Compound 4: middle estimate off by 1.9-fold (0.29 log units), on the low side; the range from low to high includes it.
By their numbers in this assay, from the lowest: compound 1; then compounds 4, 3 and 2 (each within the scatter of the next).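

In this assay dropping the phenyl brings no return toward compound 1: the change to hydroxymethyl gives a 1.3-fold lower number from compound 2 to compound 4 (0.10 log units; within the scatter) and so does not separate these two groups at this position. Compound 4 also stands with compound 3, at a 1.2-fold lower number from compound 3 to compound 4 (0.07 log units; within the scatter) here, whereas a 2.7-fold higher number from compound 1 to compound 4 (0.43 log units; beyond the scatter) leaves compound 1 alone with the lowest number of the four. Nothing available explains the place of compound 1.

Still open, from the compounds shown here alone, is whether an amine or a carboxylic acid in place of hydroxymethyl would move the number. Also open, going by these compounds, is which part of the 1-hydroxy-1-methylpropyl of compound 1 goes with its lower number.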